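From hydroxymethyl to fluoromethyl on the shared core

The source may hold more compounds than are shown below. What is called first, only, known or untested is meant among the compounds shown, and "the series" means these compounds.

In a functional assay on IM-9 cells (Homo sapiens) for antiproliferative activity (on this read-out lower numbers stand for stronger inhibition and higher numbers for weaker inhibition), compound 1 `Cc1c(F)c(=O)[nH]c(=O)n1C1O[C@H](CO)[C@@H](O)[C@H]1O` gives > 10 ug/mL as a limit and not a number. Compound 2 `O=c1cc(CO)n(C2O[C@H](CO)[C@@H](O)[C@H]2O)c(=O)[nH]1` gives > 10 ug/mL as a limit too. Compound 2 therefore has no number on this read-out, only the limit of > 10 ug/mL in this assay, at which 2 of the 2 values shown sit, to place it. Compound 3 `O=c1cc(CF)n(C2O[C@H](CO)[C@@H](O)[C@H]2O)c(=O)[nH]1` has fluoro in place of hydroxy on a saturated chain carbon bound to an aromatic carbon, with fluoro in place of hydroxy on a saturated chain carbon bound to an aromatic carbon as the counted difference from compound 2. In this assay the expected size is a step that the limit leaves unreadable from compound 2 to compound 3 and so none beyond the scatter, in neither direction. Compound 3 is estimated at 12 ug/mL with an expected range from 4 ug/mL to 40 ug/mL on this read-out.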

Compound 3, half-maximal inhibitory concentration: 9.9 ug/mL
Compound 3: middle estimate off by 1.2-fold (0.08 log units), on the high side, within the range that was stated.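

With fluoro in place of hydroxy on a saturated chain carbon bound to an aromatic carbon, the compounds shown gain their first number in this assay: compound 3 gives 9.9 ug/mL as a number and not a limit. The step reads as a number no higher from compound 2 to compound 3 (the limit leaves the size open) and goes no further. As far as these compounds go, its size stays open because compound 2 has a limit and not a number: the limit of > 10 ug/mL in this assay, at which 2 of the 3 values shown sit.

The compounds shown leave open how far the hydroxymethyl and fluoromethyl groups truly lie apart on this read-out. They also leave open what an aminomethyl group, a chloromethyl group or a longer chain would give at this place.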